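Transfer of an amine change within the series

This account rests on a few compounds, and the source may have more. Where it says the series, first, only, none or still open, it means among the compounds named here.

Measured in an assay on HEK293 cells for displacement of a labelled ligand from 5-hydroxytryptamine receptor 6 (Homo sapiens), read by scintillation counting, with a stated time of 1 h; on this read-out lower numbers stand for stronger inhibition and higher numbers for weaker inhibition:
compound 1, `C[C@H](NCc1ccc(OCCCCN2CCN(c3cccc4c3ccn4Cc3cccc(Cl)c3)CC2)cc1)C(N)=O`: 162 nM
compound 2, `C[C@H](NCc1ccc(OCCCCCN2CCN(c3cccc4c3ccn4Cc3cccc(Cl)c3)CC2)cc1)C(N)=O`: 232 nM
compound 3, `C#CCN(C)Cc1ccc(OCCCCN2CCN(c3cccc4c3ccn4Cc3cccc(Cl)c3)CC2)cc1`: 195 nM

Compounds 1 and 3 share a core and differ in one place, (methyl(propargyl)amino in place of (1-carbamoylethyl)amino on a saturated chain carbon bound to an aromatic carbon). The step this change made is a 1.2-fold higher number from compound 1 to compound 3 (0.08 log units; within the scatter), so the two amines read alike in this assay.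

Compound 2 and compound 1 share the right-hand part but differ in their cores; the difference between the two cores is not broken down here. In this assay compound 2 gives a number within the scatter of both compound 1 and compound 3, so no order among the three can be read.

Compound 4, `C#CCN(C)Cc1ccc(OCCCCCN2CCN(c3cccc4c3ccn4Cc3cccc(Cl)c3)CC2)cc1`, is not yet measured. It carries the same change on the core of compound 2 that compound 3 carries on the core of compound 1: methyl(propargyl)amino in place of (1-carbamoylethyl)amino on a saturated chain carbon bound to an aromatic carbon. The place is the same in both pairs.

The expected step from compound 2 to compound 4 is a 1.2-fold higher number from compound 2 to compound 4 (0.08 log units; within the scatter), set beside the earlier one because that step, a 1.2-fold higher number from compound 1 to compound 3 (0.08 log units; within the scatter), stayed within the scatter. Compound 4 is therefore expected to give about 280 nM in this assay, most likely between 140 nM and 560 nM.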

Compound 4, inhibition constant: 140 nM
For compound 4 the middle estimate is 2.0-fold (0.30 log units) above the measured one; measured number inside the range.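

In this assay, methyl(propargyl)amino in place of (1-carbamoylethyl)amino on the core of compound 2 gives a 1.7-fold lower number from compound 2 to compound 4 (0.22 log units; within the scatter) and this step does not differ from the one seen on the core of compound 1: the same change on two cores in this assay, a 1.2-fold higher number (0.08 log units; within the scatter) from compound 1 to compound 3 and a 1.7-fold lower number (0.22 log units; within the scatter) from compound 2 to compound 4, 2.0-fold (0.30 log units) apart, within the scatter of two such steps. On these two cores, then, the change can be carried over with the number staying within the scatter of its parent each time. This does not show a real effect of the change on either core, and two pairs say nothing about how it would behave on any other core in the series.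

Still open, from the compounds shown here alone, is whether other amines at this place, such as morpholine or dimethylamine, would also read alike on both cores. Going by these compounds, a longer chain in the core is equally open, and it is unknown whether the same change would stay within the scatter there.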